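A few compounds are considered here, and "the series" means these few. Any claim that something is new, unique, unknown or untested is made for them only; others in the source may bear on it.

Measured so far in a functional assay on RAW264.7 cells (Mus musculus) for inhibition, with a stated time of 30 min; a higher number here means a weaker inhibitor, a lower number a stronger inhibitor:
- compound 1 `C=C1C(=O)OC[C@@H]1CCOC(=O)Nc1ccc(C(C)C)cc1`: 1580 nM
- compound 2 `C=C1C(=O)OC[C@H]1CCOC(=O)Nc1ccc(C(=O)OCCCC)cc1`: 430 nM
- compound 3 `C=C1C(=O)OC[C@H]1CCOC(=O)Nc1ccc(OC)cc1`: 710 nM

Compound 3 stands second highest of the three numbers; its nearest neighbour is compound 2, its furthest compound 1.

Compound 4 `C=C1C(=O)OC[C@H]1CCOC(=O)Nc1ccc(C(C)C)cc1` carries isopropyl in place of methoxy on an aromatic carbon. Among the compounds with values here, the only measured step at this position is a 1.7-fold higher number from compound 2 to compound 3 (0.22 log units; within the scatter), a swap of one para group for another that stayed within the scatter. Within the data shown here, compound 1 also bears an isopropyl group and gives 1580 nM in this assay, but no step between compound 1 and compound 4 is computed here, so it only hints that the isopropyl may sit at the weaker end.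

For compound 4 a step of a 1.5-fold higher number from compound 3 to compound 4 (0.19 log units; within the scatter) is expected, towards a weaker inhibitor; the estimate is 1100 nM, range 450 nM to 2800 nM.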

Compound 4, half-maximal inhibitory concentration: 340 nM
Beside the measured number, compound 4's estimate is 3.2-fold (0.51 log units) above it; the measured number lies below the stated range.
By their numbers in this assay, from the lowest: compounds 4, 2 and 3 (each within the scatter of the next, the first and the last beyond it); then compound 1.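

In this assay, within the data shown here, isopropyl in place of methoxy gives a 2.1-fold lower number from compound 3 to compound 4 (0.32 log units; beyond the scatter), the first step at this position beyond the scatter, whereas a 1.3-fold lower number from compound 2 to compound 4 (0.10 log units; within the scatter) does not separate isopropyl from butoxycarbonyl. Among these compounds, the largest step so far comes with no change of group at all, a 4.6-fold lower number from compound 1 to compound 4 (0.67 log units; beyond the scatter). That step is purely one of drawn stereochemistry, with the stereocentre R in compound 1 and S in compound 4: the fact that compounds 1 and 4 differ only in the configuration as drawn

Still open, going by these compounds, is how an amine, a carboxylic acid or a longer alkyl chain would behave at this position. Also open, on these data alone, is whether the same stereocentre matters as much with methoxy or butoxycarbonyl in place of isopropyl.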